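A few compounds are considered here, and "the series" means these few. Any claim that something is new, unique, unknown or untested is made for them only; others in the source may bear on it.

Compound 1, `c1ccc2c(c1)CCC2c1ncc[nH]1`, gives 473 nM in a functional assay on CHO cells for agonist activity at Alpha-1A adrenergic receptor (Homo sapiens), read by FLIPR and calcium flux; on this read-out lower numbers stand for an effect already at smaller amounts and higher numbers for an effect only at larger amounts of compound.
Compound 2, `Cc1oncc1-c1cccc2c1CCC2c1ncc[nH]1`, gives 111 nM in this assay.

For the measured compounds named here, of these two numbers, compound 2 stands at the lower one; the only measured step, a 4.3-fold lower number from compound 1 to compound 2 (0.63 log units; beyond the scatter), separates it from compound 1. Compound 3, `c1cc(-c2cn[nH]c2)c2c(c1)C(c1ncc[nH]1)CC2`, is the next compound to be measured in this assay. It differs from compound 2 in one place: 1H-pyrazol-4-yl in place of 5-methyl-1,2-oxazol-4-yl on an aromatic carbon. Going by the values given here, the measured step bears on it only indirectly, as it shows that a five-membered aromatic ring at this position gives a modest gain over hydrogen; no measured step shows what exchanging one such ring for another does. Compound 3 is therefore expected to give about 150 nM, within a range of 50 nM to 450 nM. This estimate means a 1.4-fold higher number from compound 2 to compound 3 (0.13 log units; within the scatter), a step expected to stay within the usual scatter.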

Compound 3, half-maximal effective concentration: 14 nM
Beside the measured number, compound 3's estimate is 11-fold (1.03 log units) above it; measured number outside the range, below it.
By their numbers in this assay, from the lowest: compound 3; then compound 2; then compound 1.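

The exchange of one five-membered aromatic ring for another on this aromatic carbon proves far from neutral: in this assay, 1H-pyrazol-4-yl in place of 5-methyl-1,2-oxazol-4-yl gives a 7.9-fold lower number from compound 2 to compound 3 (0.90 log units; beyond the scatter). Set against hydrogen, 1H-pyrazol-4-yl gives a 34-fold lower number from compound 1 to compound 3 (1.53 log units; beyond the scatter), so the gain available at this position is larger than a 4.3-fold lower number from compound 1 to compound 2 (0.63 log units; beyond the scatter) had shown. The entering group brings a hydrogen-bond donor and lacks the methyl of the leaving group, but nothing available here tells which of these differences, if either, accounts for the step.

As far as these compounds go, whether a methyl group on the 1H-pyrazol-4-yl ring would keep this number remains open. So does the outcome of replacing that ring on the same carbon with a pyridine ring, an amine or a carboxylic acid.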